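The source may report more compounds than this note shows. Statements on the series, on what has been measured and on what is new or still open speak of the compounds shown alone.

Measured compounds in a physicochemical assay for lipophilicity, read by HPLC, measured as octanol-water partition; a lower number here means a more polar compound, a higher number a more lipophilic compound:
- Compound 1 `O=C(N/N=C/c1ccc2no[n+]([O-])c2c1)c1cccc(O)c1` gives 1.2
- Compound 2 `Nc1ccc(C(=O)N/N=C/c2ccc3no[n+]([O-])c3c2)cc1` gives 1.2
- Compound 3 `O=C(N/N=C/c1ccc2no[n+]([O-])c2c1)c1ccc([N+](=O)[O-])cc1` gives 0.9

All three share one core and differ only in the group on the carbonyl-bearing phenyl ring. Compound 3 has the lowest of the three numbers, but its gap to compound 1 and to compound 2 is within the scatter, so the three compounds cannot be placed in any firm order.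

Compound 4 `O=C(N/N=C/c1ccc2no[n+]([O-])c2c1)c1ccc(O)cc1` has not yet been measured. Relative to compound 3 the change is hydroxy in place of nitro on an aromatic carbon.

Within the data shown here, two measured steps bear on this. The step of no change at the digits printed from compound 1 to compound 2 (within the scatter) shows that hydroxy and amino on this ring gave matching numbers. The step of a number 0.30 log units lower from compound 2 to compound 3 (within the scatter) shows that nitro in place of amino went slightly lower, still within the scatter. Removing the nitro again in favour of hydroxy is therefore expected to move the number back up by about the same small amount, a number 0.30 log units higher from compound 3 to compound 4 (within the scatter), a step not beyond the scatter. Compound 4 is estimated at 1.2, with a range from 0.9 to 1.5.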

Compound 4, partition coefficient: 1.2
The estimate for compound 4 equals the measured number at the digits printed; low and high end bracket the measured number.
By their numbers in this assay, from the lowest: compounds 3, 1, 2 and 4 (each within the scatter of the next).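

In this assay, hydroxy in place of nitro on an aromatic carbon para to a large group gives a number 0.30 log units higher from compound 3 to compound 4 (within the scatter), so this swap does not separate the two compounds. Hydroxy in place of amino gives no change at the digits printed from compound 2 to compound 4 (within the scatter), and 4-hydroxyphenyl in place of 3-hydroxyphenyl gives no change at the digits printed from compound 1 to compound 4 (within the scatter), which adds a direct comparison of the same group at two places on the ring, and that comparison also stays within the scatter. Nothing in the data available here offers an explanation for these numbers.

The compounds shown leave open whether a carboxylic acid, a dimethylamino group or a longer alkyl chain at this position would move the number beyond the scatter. They also leave open whether a methoxy group would match hydroxy here.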